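Working notes: from compound 3 to compound 4

The compounds below may be only part of what the source reports. "The series", "measured", "known", "first", "only" and "open" are said of these compounds alone.

Measured so far in a functional assay on MCF7 cells (Homo sapiens) for antiproliferative activity, read by MTT assay, with a stated time of 72 h; on this read-out lower numbers stand for stronger inhibition and higher numbers for weaker inhibition:
- compound 1 `O=C1COc2ccc(-c3cnc4ccccc4c3)cc2N1c1ccc(Cl)cc1`: > 40000 nM, which is a limit of the assay and not a number
- compound 2 `O=C1COc2ccc(-c3cnc(Cl)c(NS(=O)(=O)c4ccc(F)cc4)c3)cc2N1c1ccc(Cl)cc1`: 32800 nM
- compound 3 `COc1ncc(-c2ccc3c(c2)N(c2ccc(Cl)cc2)C(=O)CO3)cc1NS(=O)(=O)c1ccc(F)cc1`: 27600 nM

Among the two numbers, compound 3 has the lowest; its nearest neighbour is compound 2, and the one measured step, a 1.2-fold lower number from compound 2 to compound 3 (0.07 log units; within the scatter), lies within the scatter, so no order between compound 2 and compound 3 can be read from it. Compound 1 sits at the limit (the limit of > 40000 nM in this assay, at which 1 of the 3 values shown sits).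

Compound 4 `COc1ncc(-c2ccc3c(c2)N(C2CC2)C(=O)CO3)cc1NS(=O)(=O)c1ccc(F)cc1` differs from compound 3 by cyclopropyl in place of 4-chlorophenyl on an amide-type nitrogen in a ring. Within the data shown here, none of the measured steps touches this position: the step from compound 2 to compound 3 concerns a different place, and compound 1 lacks the sulfonamide altogether, so its limit does not speak to the change at the amide-type nitrogen. No direction can be expected beyond the scatter from the data shown.

Compound 4 is therefore estimated near compound 3, with a wide range, at 30000 nM (from 8000 nM to 120000 nM). This estimate means a step of a 1.1-fold higher number from compound 3 to compound 4 (0.04 log units; within the scatter), expected to stay within the scatter.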

Compound 4, half-maximal inhibitory concentration: 35200 nM
Compound 4: the middle estimate sits 1.2-fold (0.07 log units) below what was measured, and the stated range covers the measured number.
By their numbers in this assay, from the lowest: compounds 3, 2 and 4 (each within the scatter of the next). At a limit, above all of these: compound 1.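

In this assay, among these compounds, the amide-type nitrogen in a ring is read for the first time, and cyclopropyl in place of 4-chlorophenyl gives a 1.3-fold higher number from compound 3 to compound 4 (0.11 log units; within the scatter) as its only step. Across this one change, from seven heavy atoms with an aromatic ring to three with a non-aromatic ring, the two groups cannot be told apart at this position. The numbers for compound 3 and compound 4 also stay in the same weak range as compound 2, while compound 1 alone carries a limit and not a number: the limit of > 40000 nM in this assay, at which 1 of the 4 values shown sits.

Going by these compounds, whether any group on this nitrogen can move the number beyond the scatter stays open. Among the compounds shown here, a longer alkyl chain, an amine or a carboxylic acid at this position would test that, and the series so far gives no direction for any of them.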